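Replacing 3-(dimethylamino)phenoxy with 2-chloro-4-fluorobenzyl on the core

The source may hold more compounds than are shown below. What is called first, only, known or untested is meant among the compounds shown, and "the series" means these compounds.

In a physicochemical assay for acid dissociation, three compounds have been measured:
Compound 1 `COc1ccc(F)cc1CNCCCNc1ccnc2cc(Cc3ccc(F)cc3Cl)ccc12` gives 9.47.
Compound 2 `COc1cccc(CNCCCNc2ccnc3cc(Cc4cccc(C(F)(F)F)c4)ccc23)c1O` gives 9.47.
Compound 3 `COc1cccc(CNCCCNc2ccnc3cc(Oc4cccc(N(C)C)c4)ccc23)c1O` gives 9.28.

Within the data shown here, compound 3 stands lowest of the three, but only within the scatter: the single one-place step, a number 0.19 log units lower from compound 2 to compound 3 (within the scatter), did not move the number beyond it, and compound 1 sits the same small distance away.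

Compound 4 `COc1cccc(CNCCCNc2ccnc3cc(Cc4ccc(F)cc4Cl)ccc23)c1O` differs from compound 3 by 2-chloro-4-fluorobenzyl in place of 3-(dimethylamino)phenoxy on an aromatic carbon. Among the measured compounds shown here, the one measured step bearing on this, a number 0.19 log units lower from compound 2 to compound 3 (within the scatter), exchanged a benzyl group for the same phenoxy group without a real shift, and compound 1 already carries this 2-chloro-4-fluorobenzyl group at a nearly identical value. Compound 4 is therefore expected to give 9.45, between 9.15 and 9.75. That estimate means an expected step of a number 0.17 log units higher from compound 3 to compound 4 (within the scatter), within the scatter.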

Compound 4, acid dissociation constant: 9.47
Estimate against measurement, compound 4: 0.02 log units below; measured number inside the range.
By their numbers in this assay, from the lowest: compounds 3, 1, 2 and 4 (each within the scatter of the next).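

In this assay the exchange on the aromatic carbon gives a number 0.19 log units higher from compound 3 to compound 4 (within the scatter) and so 2-chloro-4-fluorobenzyl and 3-(dimethylamino)phenoxy cannot be told apart at this position. Likewise, 2-chloro-4-fluorophenyl in place of 3-(trifluoromethyl)phenyl gives no change at the digits printed from compound 2 to compound 4 (within the scatter) and 2-hydroxy-3-methoxyphenyl in place of 5-fluoro-2-methoxyphenyl gives no change at the digits printed from compound 1 to compound 4 (within the scatter) so neither change moves the number beyond the scatter.

As far as these compounds go, whether a carboxylic acid or a nitrile on this aromatic carbon would move the number remains open. Nothing available explains why these changes leave the number within the scatter.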